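From Ethoxy to Sec-Butoxy on Compound 2

The source may hold more compounds than are shown below. What is called first, only, known or untested is meant among the compounds shown, and "the series" means these compounds.

Of the compounds shown here, two have been tested so far in an ADME assay on RAW264.7 cells (Mus musculus) for cytotoxicity, read by MTT assay, with a stated time of 24 h, in the absence of a further agent; a lower number here means a stronger inhibitor, a higher number a weaker inhibitor. Compound 1 `O=C1OC(Cc2nc(-c3ccccc3)no2)c2ccccc21` gives > 40000 nM, which is a limit of the assay and not a number. Compound 2 `CCOc1ccc(C(O)C2OC(=O)c3c(OC)cc(OC)cc32)cc1` gives > 40000 nM, which is also a limit and not a number. Compound 2 therefore has no exact value, and the results so far amount to the limit of > 40000 nM in this assay, at which 2 of the 2 values shown sit.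

Compound 3 `CCC(C)Oc1ccc(C(O)C2OC(=O)c3c(OC)cc(OC)cc32)cc1` keeps the core of compound 2 and differs in a single place: ethyl in place of hydrogen on a saturated chain carbon bound to an oxygen on an aromatic ring and a saturated chain carbon. Put another way, ethoxy becomes sec-butoxy. Among the measured compounds shown here, no measured pair of compounds shows what a change of this kind does in this assay, so the forecast has little to rest on. For the measured compounds named here, the only close guide is compound 2 at its limit of > 40000 nM, so no step beyond the usual scatter is expected. In numbers, the estimated change is a step of a number no higher from compound 2 to compound 3 (the limit leaves the size open). For compound 3, the estimated value is 40000 nM, with an expected range from 20000 nM to 80000 nM, and the assay may well report only a limit again.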

Compound 3, half-maximal inhibitory concentration: > 40000 nM
Compound 3: a limit, no number; the forecaster's own chance of this, stated with the estimate: 85%; the middle value lies on the limit itself.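

In this assay compound 3 gives > 40000 nM, which is a limit of the assay and not a number. Among the compounds shown here, compound 2 also stands at a limit, so no step from ethoxy to sec-butoxy can be read between compound 2 and compound 3. The compounds shown leave open what exact value any of them has, because all end at the same point: the limit of > 40000 nM in this assay, at which 3 of the 3 values shown sit.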